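The source may hold more compounds than are shown below. What is called first, only, known or untested is meant among the compounds shown, and "the series" means these compounds.

Among the compounds with values here, compound 1 `CC(C)C[C@@H](NC(=S)Nc1ccccc1)c1nc2ccccc2[nH]1` gives 11900 nM in a functional assay on MCF7 cells (Homo sapiens) for cytotoxicity, read by MTT assay (on this read-out higher numbers stand for weaker inhibition and lower numbers for stronger inhibition), the lower of the two numbers measured so far. Its stereoisomer, compound 2 `CC(C)C[C@H](NC(=S)Nc1ccccc1)c1nc2ccccc2[nH]1`, gives 25800 nM in this assay, and the step of a 2.2-fold higher number from compound 1 to compound 2 (0.34 log units; beyond the scatter) rests on configuration alone (the fact that compounds 1 and 2 differ only in the configuration as drawn). Compound 3 `CC(C)[C@@H](NC(=S)Nc1ccccc1)c1nc2ccccc2[nH]1` differs from compound 1 by isopropyl in place of isobutyl on a saturated chain carbon bound to an amide-type nitrogen and an aromatic carbon. Within the data shown here, the one measured step concerns configuration only; no measured step bears on this change, and no step beyond the scatter is expected in this assay in either direction. The expected step is a 1.0-fold higher number from compound 1 to compound 3 (0.00 log units; within the scatter). Compound 3 is therefore estimated at 12000 nM, within 5000 nM to 30000 nM.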

Compound 3, half-maximal inhibitory concentration: "not active" (no number reported)
Compound 3: no number reported, and the estimate cannot be compared.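

Within the data shown here, compound 3 is reported as not active in this assay without a number, so no step from compound 1 can be read. How far isopropyl in place of isobutyl moves this read-out stays open, and nothing shown bears on this result.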